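Swapping Nitro for Chloro in a Macrophage Tolerance Test

A few compounds are considered here, and "the series" means these few. Any claim that something is new, unique, unknown or untested is made for them only; others in the source may bear on it.

- compound 1 `O=C(/N=C(/NCc1ccccc1)Nc1ccc(C(F)(F)F)cc1)c1ccccc1`: 18600 nM
- compound 2 `O=C(/N=C(/NCc1ccccc1)Nc1ccc([N+](=O)[O-])cc1)c1ccccc1`: 802000 nM

Both values come from an ADME assay on cells (Peritoneal macrophage, Mus musculus) for cytotoxicity, read by MTT assay, with a stated time of 24 h; a higher number here means that more compound is tolerated, a lower number that less compound is tolerated. Of the two measured compounds, compound 2, at 802000 nM, has the higher number, so cells tolerate more of it than of compound 1, at 18600 nM.

The next compound is compound 3 `O=C(/N=C(/NCc1ccccc1)Nc1ccc(Cl)cc1)c1ccccc1`. It carries chloro in place of nitro on an aromatic carbon, para to a large group: chloro in place of nitro on an aromatic carbon.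

Among the measured compounds shown here, only one measured step bears on this change: a 43-fold higher number from compound 1 to compound 2 (1.63 log units; beyond the scatter). That large step put nitro in place of trifluoromethyl at the same spot. For the measured compounds named here, compound 3 loses the nitro too, but no measurement yet covers chloro, so a lower number is expected, with a step somewhat smaller than that one. The estimate means a 13-fold lower number from compound 2 to compound 3 (1.13 log units; beyond the scatter). For compound 3 the expected value is 60000 nM, with an estimated range from 15000 nM to 300000 nM.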

Compound 3, half-maximal cytotoxic concentration: 827000 nM
For compound 3 the middle estimate is 14-fold (1.14 log units) below the measured one, and the stated range ends below it.
By their numbers in this assay, from the lowest: compound 1; then compounds 2 and 3 (each within the scatter of the next).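

In this assay, chloro and nitro at this spot on the ring cannot be told apart: the swap gives a 1.0-fold higher number from compound 2 to compound 3 (0.01 log units; within the scatter) and so lies within the usual scatter. Compound 1 now stands alone, with chloro in place of its trifluoromethyl giving a 44-fold higher number from compound 1 to compound 3 (1.65 log units; beyond the scatter), a step of much the same size as the one seen with nitro, a 43-fold higher number from compound 1 to compound 2 (1.63 log units; beyond the scatter), so two different replacements for trifluoromethyl reach the same level. Nothing available explains why compound 1 differs from the other two.

Going by these compounds, whether trifluoromethyl is unusual among groups at this spot remains open, since a methyl group, a methoxy group or an amine there could fall at either level. It is also unknown whether the same pattern would hold at another place on this ring.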